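This account rests on a few compounds, and the source may have more. Where it says the series, first, only, none or still open, it means among the compounds named here.

Compound 1 `N#Cc1ccc(C2OCC(C/C=C\CCC(=O)O)C(c3cccnc3)O2)cc1` was measured in a functional assay for inhibition, with Homo sapiens as the target (on this read-out lower numbers stand for tighter binding and higher numbers for weaker binding), where compound 1 gives 1290 nM. Compound 2 `N#Cc1ccccc1C1OCC(C/C=C\CCC(=O)O)C(c2cccnc2)O1` differs from it only by a 2-cyanophenyl in place of 4-cyanophenyl on a saturated ring carbon, and in this assay compound 2 gives 245 nM, the step being a 5.3-fold lower number from compound 1 to compound 2 (0.72 log units; beyond the scatter). Among the measured compounds shown here, compound 2 thus holds the lowest of the two numbers measured so far, with compound 1 as its only neighbour. Compound 3 `O=C(O)CC/C=C\CC1COC(c2cccc3ccccc23)OC1c1cccnc1` has not been measured; its change from compound 2 is naphthalen-1-yl in place of 2-cyanophenyl on a saturated ring carbon. For the measured compounds named here, the single measured step, a 5.3-fold lower number from compound 1 to compound 2 (0.72 log units; beyond the scatter), swapped one cyanophenyl for another at the same place, whereas here the whole 2-cyanophenyl gives way to naphthalen-1-yl, so that step bears on this one only loosely. A modest shift is expected, more likely towards a higher number, so compound 3 is estimated at 500 nM in this assay, within 120 nM to 2500 nM. That estimate means an expected step of a 2.0-fold higher number from compound 2 to compound 3 (0.31 log units; beyond the scatter).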

Compound 3, dissociation constant: 631 nM
Estimate against measurement, compound 3: 1.3-fold (0.10 log units) below, and the stated range covers the measured number.
By their numbers in this assay, from the lowest: compound 2; then compound 3; then compound 1.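

In this assay, the position between two ring oxygen atoms turns out not to need a nitrile: naphthalen-1-yl, which has none and carries a second aromatic ring, gives a 2.0-fold lower number from compound 1 to compound 3 (0.31 log units; beyond the scatter) and so still improves on the 4-cyanophenyl group. It does not match the 2-cyanophenyl group, however, as the change gives a 2.6-fold higher number from compound 2 to compound 3 (0.41 log units; beyond the scatter). The group without a nitrile therefore lands in the middle of the two cyanophenyl compounds, and nothing available explains this order.

Still open, going by these compounds, is how a plain phenyl group, with a single ring and no nitrile, would read at this position, which would help separate the effect of removing the nitrile from that of adding a ring. The compounds shown also leave open whether a 2-chlorophenyl or 2-aminophenyl group could match the 2-cyanophenyl group.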